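This account rests on a few compounds, and the source may have more. Where it says the series, first, only, none or still open, it means among the compounds named here.

Compound 1 `C=C(Br)C(=O)Nc1ccc2[nH]c(C(=O)O)cc2c1` is measured in a functional assay on K562 cells (Homo sapiens) for antiproliferative activity (a lower number here means a stronger inhibitor, a higher number a weaker inhibitor), where compound 1 gives 5600 nM. Compound 3 `C=C(Br)C(=O)Nc1ccc2sc(C(=O)O)cc2c1` gives 5000 nM in this assay, a gap to compound 1 that lies within the scatter. Compound 2 `C=C1CC(COc2cc(C(=O)O)n(C)n2)(c2ccc(Cl)cc2)OC1=O` reaches only the limit of > 10000 nM in this assay, which is a limit and not a number, as in the limit of > 10000 nM in this assay, at which 1 of the 3 values shown sits. Compound 4 `C=C(Br)C(=O)Nc1ccc2c(c1)cc(C(=O)O)n2C` differs from compound 1 by methyl in place of hydrogen on an aromatic nitrogen, a methyl in place of hydrogen on an aromatic nitrogen. Within the data shown here, no pair of measured compounds shows this change, so only a small step in this assay, if any beyond the scatter, is expected here, probably toward a weaker inhibitor. Compound 4 is therefore expected to give 7000 nM, within 3000 nM to 15000 nM, a step of a 1.3-fold higher number from compound 1 to compound 4 (0.10 log units; within the scatter).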

Compound 4, half-maximal inhibitory concentration: 3370 nM
Compound 4: the middle estimate sits 2.1-fold (0.32 log units) above what was measured; measured number inside the range.
By their numbers in this assay, from the lowest: compounds 4, 3 and 1 (each within the scatter of the next). At a limit, above all of these: compound 2.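

In this assay the record shows a 1.7-fold lower number from compound 1 to compound 4 (0.22 log units; within the scatter) when methyl takes the place of hydrogen on the aromatic nitrogen, next to the ring atom that bears a carboxy group. Among these compounds, as the first pair here differing in one place, it shows that this nitrogen can carry methyl with a step that stays within the scatter, so the hydrogen there is not needed to keep this level of activity. As far as these compounds go, whether this nitrogen would also accept an ethyl group, a longer chain or a chain ending in an amine remains open. Nothing shown here gives a reason for this step.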